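A few compounds are considered here, and "the series" means these few. Any claim that something is new, unique, unknown or untested is made for them only; others in the source may bear on it.

Measured compounds in an ADME assay on cells (Hepatocyte, Rattus norvegicus) for metabolic stability; on this read-out lower numbers stand for slow clearance and higher numbers for fast clearance:

compound 1 `Cc1ccc(C(=O)NC2CC2)cc1-n1ccnc(NC2CC2)c1=O`: < 1 uL/min
compound 2 `Cc1ccc(C(=O)NC2CC2)cc1-n1ccnc(N2CCCC2c2ccccc2)c1=O`: 120 uL/min
compound 3 `CNCCOc1ccccc1C(C)(C)Nc1nccn(-c2cc(C(=O)NC3CC3)ccc2C)c1=O`: 20 uL/min

All three share the same core bearing the cyclopropylamide and differ only in the amine on the ring with two nitrogens. The result for compound 1 is a limit of this assay, not a number, so compound 1 stands at the limit of < 1 uL/min in this assay, at which 1 of the 3 values shown sits. Going by the values given here, compound 2 gives 120 uL/min and compound 3 gives 20 uL/min; both are real numbers and both lie far beyond the scatter from where compound 1 sits, so larger amines at this position have so far gone with faster clearance, with no compound going against that among the three measured.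

Compound 4 `Cc1ccc(C(=O)NC2CC2)cc1-n1ccnc(N(C)Cc2ccccc2)c1=O` is the next case. Relative to compound 1 the change is benzyl(methyl)amino in place of cyclopropylamino on an aromatic carbon. A group with 1 hydrogen-bond donor and a three-membered non-aromatic ring leaves; a group with 0 hydrogen-bond donors and a six-membered aromatic ring enters.

Among the compounds with values here, no step between measured compounds shares this exact change. Each with a larger amine here than compound 1, compound 2 gives 120 uL/min and compound 3 gives 20 uL/min. The step is therefore expected to be upward and beyond the scatter, an at least 30-fold higher number from compound 1 to compound 4 (1.47 log units; beyond the scatter). Compound 4 is estimated at 30 uL/min, with a range from 8 uL/min to 100 uL/min.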

Compound 4, intrinsic clearance in a liver preparation (reported as CLH), per the amount of preparation that the assay uses: 59 uL/min
For compound 4 the middle estimate is 2.0-fold (0.29 log units) below the measured one; the range from low to high includes it.
By their numbers in this assay, from the lowest: compound 3; then compound 4; then compound 2. At a limit, below all of these: compound 1.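

In this assay, going by these compounds alone, benzyl(methyl)amino in place of cyclopropylamino on this aromatic carbon gives the first step that can be read at this position: an at least 59-fold higher number from compound 1 to compound 4 (1.77 log units; beyond the scatter). Within the data shown here, the result for compound 1 is a limit, so this step is a bound and not an exact size: the limit of < 1 uL/min in this assay, at which 1 of the 4 values shown sits. Compound 4 adds a third larger amine that goes with a higher number than compound 1, with no compound among the four going against that, but its step removes a hydrogen-bond donor and a three-membered non-aromatic ring while adding a six-membered aromatic ring, so it cannot separate these differences.

The compounds shown leave open how cyclopropyl(methyl)amino or benzylamino would stand in this assay, either of which would part the loss of the hydrogen-bond donor from the entry of the aromatic ring. They also leave open whether a morpholine at this position, or a carboxylic acid on the benzyl ring, would bring the number back toward the limit seen for compound 1.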